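The source may hold more compounds than are shown below. What is called first, only, known or untested is meant among the compounds shown, and "the series" means these compounds.

Measured so far in an assay on HEK293 cells for inhibition of solute carrier family 22 member 12 (Homo sapiens), read by scintillation counting, with a stated time of 12 min; a lower number here means a stronger inhibitor, a higher number a weaker inhibitor:
- compound 1 `COCCOc1ccc2nccc(SC3(C(=O)O)CCC3)c2c1` gives 207 nM
- compound 2 `O=C(O)C1(Sc2ccnc3ccc(C(F)(F)F)cc23)CCC1` gives 61.2 nM

Among the measured compounds shown here, compound 2 holds the lowest number of the two in this assay; its nearest neighbour is compound 1, and the one recorded step, a 3.4-fold lower number from compound 1 to compound 2 (0.53 log units; beyond the scatter), separates them by more than the scatter. That step concerns a trifluoromethyl in place of 2-methoxyethoxy on an aromatic carbon of the shared core.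

Compound 3 `O=C(O)C1(Sc2ccnc3ccc(-c4ccccc4F)cc23)CCC1` has not been measured. Relative to compound 2 the change is 2-fluorophenyl in place of trifluoromethyl on an aromatic carbon. For the measured compounds named here, no measured step touches an aryl group at this position; the single step from compound 1 to compound 2 shows only that the substituent on that aromatic carbon can move the number by a modest amount, and it offers no direction for a 2-fluorophenyl. With the thioether and carboxylic acid of compound 2 kept intact, the expectation is a step from compound 2 to compound 3 of a 1.2-fold lower number from compound 2 to compound 3 (0.09 log units; within the scatter), within or close to the scatter. Compound 3 is therefore estimated at 50 nM in this assay, with a range of 15 nM to 200 nM.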

Compound 3, half-maximal inhibitory concentration: 333 nM
The estimate for compound 3 lay 6.7-fold (0.82 log units) below the measured number; the whole stated range lies below it.
By their numbers in this assay, from the lowest: compound 2; then compounds 1 and 3 (each within the scatter of the next).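

Working from this assay, the step of a 5.4-fold higher number from compound 2 to compound 3 (0.74 log units; beyond the scatter) shows that this aromatic carbon does not accept every replacement for trifluoromethyl equally: 2-fluorophenyl, with its six-membered aromatic ring of carbon only, does not hold the number of compound 2. The step of a 1.6-fold higher number from compound 1 to compound 3 (0.21 log units; within the scatter) leaves 2-fluorophenyl and 2-methoxyethoxy unresolved from each other, so among the three groups at this carbon only trifluoromethyl stands apart, with compound 2 beyond the scatter of both compound 1 and compound 3. No supporting measurement accompanies these numbers, so the result cannot be assigned to any property of the groups.

From the compounds shown here alone, whether the shift belongs to the aromatic ring itself or to its fluorine remains open, and a plain phenyl or a 4-fluorophenyl at the same carbon would bear on that question. Equally open, going by these compounds, is whether small groups such as a chlorine atom, a methyl or a nitrile would stay near compound 2, and whether an amine or a longer chain at this carbon would be tolerated.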